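This account rests on a few compounds, and the source may have more. Where it says the series, first, only, none or still open, it means among the compounds named here.

Measured compounds and their values:
compound 1, `Oc1cc(C(F)(F)F)ccc1-c1nc(-c2ccccc2O)n(-c2ccc(Cl)cc2)n1`, 96.1%
compound 2, `Oc1cc(C(F)(F)F)ccc1-c1nc(-c2ccccc2O)n(-c2cccc(C(F)(F)F)c2)n1`, 99.9%
compound 3, `COc1cccc(-n2nc(-c3ccc(C(F)(F)F)cc3O)nc2-c2ccccc2O)c1`, 106%

All three were tested in a functional assay on PC-12 cells (Rattus norvegicus) for cytotoxicity, read by MTT assay, with stated times of 2 h and 24 h, tested at 10 uM; a lower number here means a weaker effect, a higher number a stronger effect of the compound at the concentration tested. Compound 3 shows the highest of the three numbers, but its nearest neighbour, compound 2, lies within the scatter of it (a number 6.1 percentage points higher from compound 2 to compound 3 (within the scatter)), and the furthest, compound 1, does so as well (a number 9.9 percentage points higher from compound 1 to compound 3 (within the scatter)). The three values are therefore best read as one level, and compound 3 is not set apart from the others.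

Compound 4, `Cc1ccc(-n2nc(-c3ccc(C(F)(F)F)cc3O)nc2-c2ccccc2O)c(C)c1`, differs from compound 3 in one place: 2,4-dimethylphenyl in place of 3-methoxyphenyl on an aromatic nitrogen. The measured steps that bear on this are the three that exchange the group on the same aromatic nitrogen, namely a number 3.8 percentage points higher from compound 1 to compound 2 (within the scatter), a number 9.9 percentage points higher from compound 1 to compound 3 (within the scatter) and a number 6.1 percentage points higher from compound 2 to compound 3 (within the scatter). Each of these stayed within the scatter, whether a chlorine-bearing, a trifluoromethyl-bearing or a methoxy-bearing phenyl sat there. Compound 4 is therefore expected to give no step beyond the scatter, in either direction, as its estimated step of a number 3 percentage points lower from compound 3 to compound 4 (within the scatter) shows. Compound 4 is expected at 103%, with a range from 91% to 115%.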

Compound 4, a percentage reported as activity, at one concentration (the size of the read-out at that concentration, not a potency): 106%
Compound 4: middle estimate off by 3 percentage points, on the low side; measured number inside the range.
By their numbers in this assay, from the lowest: compounds 1, 2, 3 and 4 (each within the scatter of the next).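

The exchange on the aromatic nitrogen, read in this assay, shows that 2,4-dimethylphenyl in place of 3-methoxyphenyl leaves the reading at one level (no change at the digits printed from compound 3 to compound 4 (within the scatter)), and the same holds when this group is set against the other two aryl groups (a number 6.1 percentage points higher from compound 2 to compound 4 (within the scatter); a number 9.9 percentage points higher from compound 1 to compound 4 (within the scatter)). Among these compounds, what the earlier compounds did not show is that this position also keeps that level with a group built of carbon alone, with no chlorine, fluorine or oxygen, and with no hydrogen-bond acceptor where 3-methoxyphenyl has one. No measurement at hand explains why these exchanges leave the reading at one level.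

As far as these compounds go, all four compounds carry a substituted phenyl on this nitrogen, so it stays open whether something of another kind there, such as a benzyl group, a longer alkyl chain, a carboxylic acid or an amine, would move the reading beyond the scatter. The 2-hydroxyphenyl group and the hydroxyl on the trifluoromethyl-bearing ring are also the same throughout, so the compounds shown say nothing about replacing either hydroxyl with a methoxy group.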